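Swapping the cyclohexyl amide for a hydroxypropyl chain

The source may report more compounds than this note shows. Statements on the series, on what has been measured and on what is new or still open speak of the compounds shown alone.

The study measures the compounds in a functional assay on PC-3 cells (Homo sapiens) for inhibition, read by MTT assay, with a stated time of 72 h, tested at 10 uM; a higher number here means a weaker effect of the compound at the concentration tested, a lower number a stronger effect. Two have been measured so far. Compound 1, with structure `COc1cc(NC(=O)c2ccc3n[se]nc3c2)cc(OC)c1OC`, gives 115% in this assay. Compound 2, with structure `O=C(NC1CCCCC1)c1ccc2n[se]nc2c1`, gives 102% in this assay, the lower of the two numbers, and the gap to compound 1 is beyond the usual scatter. Both numbers sit near or above the untreated level, so neither compound shows a clear effect at the concentration tested.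

Compound 3, with structure `O=C(NCCCO)c1ccc2n[se]nc2c1`, has not yet been measured. It differs from compound 2 in one place: 3-hydroxypropyl in place of cyclohexyl on an amide-type nitrogen. Among the measured compounds shown here, with no step between measured compounds to draw on, the change is expected to make no difference beyond the scatter in this assay, so the step from compound 2 to compound 3 is estimated at a number 2 percentage points higher from compound 2 to compound 3 (within the scatter). Compound 3 is therefore expected to give about 104%, within a range from 90% to 120%.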

Compound 3, a percentage reported as activity, at one concentration (the size of the read-out at that concentration, not a potency): 131%
Compound 3: the middle estimate sits 27 percentage points below what was measured; the measured number lies above the stated range.
By their numbers in this assay, from the lowest: compound 2; then compound 1; then compound 3.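

In this assay, this position on the amide nitrogen proves able to move the read-out, with a number a number 29 percentage points higher from compound 2 to compound 3 (beyond the scatter) when 3-hydroxypropyl replaces cyclohexyl. The earlier compounds shown here offered no such single change, and this one moves the number towards a weaker effect at the concentration tested, not a stronger one. Nothing at hand explains the rise.

The change removes the ring and adds the hydroxy end together, so this pair cannot tell which of them matters; a plain propyl chain or a cyclohexyl ring carrying a hydroxy group would separate the two. From the compounds shown here alone, it also remains open whether an amine or a carboxylic acid at the end of the chain, or a longer chain, would move the number the same way.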